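A few compounds are considered here, and "the series" means these few. Any claim that something is new, unique, unknown or untested is made for them only; others in the source may bear on it.

Measured so far in an assay on isolated protein for inhibition of cathepsin S (Homo sapiens); a higher number here means a weaker inhibitor, a lower number a stronger inhibitor:
compound 1 `C[C@@H]1CN(C(=O)[C@H](CC2CCCCC2)OC(=O)N[C@@H](C)CN2CC(C)(C)c3cc(F)ccc32)C[C@H](C)O1` gives 297 nM
compound 2 `C[C@@H](CN1CC(C)(C)c2cc(F)ccc21)NC(=O)O[C@@H](CC1CCCCC1)C(=O)N1CCCCC1` gives 39 nM

Among these two numbers compound 2 stands lowest, and its nearest neighbour is compound 1, the step being a 7.6-fold lower number from compound 1 to compound 2 (0.88 log units; beyond the scatter). That single step, which is the only one measured so far, already changed the group on the carbonyl carbon and it lowered the number. Compound 3 `C[C@@H](CN1CC(C)(C)c2cc(F)ccc21)NC(=O)O[C@@H](CC1CCCCC1)C(=O)N1CCN(S(C)(=O)=O)CC1` alters the same position again: 4-(methylsulfonyl)piperazin-1-yl in place of piperidin-1-yl on a carbonyl carbon. For the measured compounds named here, no measured pair shows this particular exchange, so the expectation for compound 3 rests only on the fact that this position is sensitive, as the step from compound 1 to compound 2 shows. A step in either direction is therefore possible, and the estimate for compound 3 is set a little above compound 2, at an expected 90 nM with a range from 25 nM to 350 nM, which means an expected step of a 2.3-fold higher number from compound 2 to compound 3 (0.36 log units; beyond the scatter).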

Compound 3, inhibition constant: 1080 nM
Compound 3: middle estimate off by 12-fold (1.08 log units), on the low side; the measured number lies above the stated range.
By their numbers in this assay, from the lowest: compound 2; then compound 1; then compound 3.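

In this assay the position on the carbonyl carbon now proves able to move the number up as well as down: 4-(methylsulfonyl)piperazin-1-yl in place of piperidin-1-yl brings a 28-fold higher number from compound 2 to compound 3 (1.44 log units; beyond the scatter) as the change, larger than the earlier 7.6-fold lower number from compound 1 to compound 2 (0.88 log units; beyond the scatter) in the opposite direction. The same group also falls behind 2,6-dimethylmorpholin-4-yl with a 3.6-fold higher number from compound 1 to compound 3 (0.56 log units; beyond the scatter) as its step, which leaves compound 3 the weakest of the three and compound 2 the strongest. Nothing available here explains this order.

Still open, from the compounds shown here alone, is whether the rise belongs to the methylsulfonyl group or to the second ring nitrogen, which plain piperazin-1-yl or 4-methylpiperazin-1-yl would separate. Morpholin-4-yl without its two methyl groups would likewise show what those methyl groups contribute.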